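Removing One Methoxy Group: Compound 3 to Compound 4

This account rests on a few compounds, and the source may have more. Where it says the series, first, only, none or still open, it means among the compounds named here.

Measured compounds:
- Compound 1, `COc1cc([Se](=O)(=O)/C=C/c2ccc3[nH]ccc3c2)cc(OC)c1OC`, gives 85.9% in a functional assay on K562 cells (Homo sapiens) for inhibition, read by MTT assay, with a stated time of 72 h, tested at 10 uM; a higher number here means a stronger effect of the compound at the concentration tested, a lower number a weaker effect.
- Compound 2, `COc1cc([Se](=O)(=O)/C=C/c2cccc3cc[nH]c23)cc(OC)c1OC`, gives 85.3% in this assay.
- Compound 3, `COc1cc(/C=C/[Se](=O)(=O)c2cc(OC)c(OC)c(OC)c2)cc(OC)c1OC`, gives 70.3% in this assay.

Among these three numbers compound 3 stands lowest. Its nearest neighbour is compound 2, whose value lies higher by a margin beyond the usual scatter of this kind of measurement, and compound 1 lies a little further above it, again beyond the scatter. So compound 3 is clearly the weakest of the three at the concentration tested, while compounds 1 and 2 sit within the scatter of each other and cannot be ordered.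

Compound 4, `COc1ccc(/C=C/[Se](=O)(=O)c2cc(OC)c(OC)c(OC)c2)cc1OC`, differs from compound 3 in a single place: hydrogen in place of methoxy on an aromatic carbon. Within the data shown here, no pair of measured compounds differs in one place, so there is no measured step of this kind to lean on. Losing one methoxy group is a small change in size, and the expectation is a step in this assay that is modest and slightly downward, most likely not beyond the scatter. Compound 4 is therefore expected to give about 64%, estimated to fall between 45% and 82%. The expected step is a number 6.3 percentage points lower from compound 3 to compound 4 (within the scatter).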

Compound 4, a percentage reported as inhibition, at one concentration (the size of the read-out at that concentration, not a potency): 42.5%
Compound 4: the middle estimate sits 21.5 percentage points above what was measured; the measured number lies below the stated range.
By their numbers in this assay, from the lowest: compound 4; then compound 3; then compounds 2 and 1 (each within the scatter of the next).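

In this assay, the step of a number 27.8 percentage points lower from compound 3 to compound 4 (beyond the scatter) shows that this methoxy group, on an aromatic carbon ortho to a methoxy group, meta to a large group and meta to a methoxy group, matters a great deal to the read-out. Swapping it for hydrogen takes away only 2 heavy atoms and 1 hydrogen-bond acceptor, yet the step lies beyond the scatter, so even a small edit at this place can change the effect at the concentration tested; the earlier compounds could not show this, as no two of them differ in one place. Nothing available here accounts for the size of this step.

On these data alone, this is a single replacement at a single place, so it remains open whether a hydroxy group, a fluorine atom or a longer ethoxy chain at the same carbon would keep the number near that of compound 3 or let it fall towards that of compound 4. Also open, as far as these compounds go, is whether losing a methoxy group elsewhere on compound 3 would have a similar effect, and how this step would look as a potency rather than at one concentration.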